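A few compounds are considered here, and "the series" means these few. Any claim that something is new, unique, unknown or untested is made for them only; others in the source may bear on it.

Compound 1 `Cc1n[nH]c(C(=O)O)c1Cc1cccc(-c2ccccc2F)c1` gives 22% in an assay on isolated protein for inhibition of 2-Hydroxyacid oxidase 2 (Homo sapiens), tested at 10 uM; a higher number here means a stronger effect of the compound at the concentration tested, a lower number a weaker effect.
Compound 2 `Cc1n[nH]c(C(=O)O)c1Cc1ccc(C#N)cc1` gives 6% in this assay.
Compound 3 `Cc1n[nH]c(C(=O)O)c1Cc1cc2ccccc2o1` gives 66% in this assay.

Among these three numbers compound 1 stands second highest: compound 2 lies lower by an amount beyond the usual scatter, and compound 3 lies higher, also beyond it. Compound 4 `Cc1n[nH]c(C(=O)O)c1Cc1cccc(C(=O)O)c1` has not yet been measured in this assay. It differs from compound 1 in one place: carboxy in place of 2-fluorophenyl on an aromatic carbon. No pair of measured compounds isolates this change, so what follows is an expectation only, resting on the three numbers shown. Compound 2 and compound 3 carry neither the leaving nor the entering group, so they offer no direct guide. The step from compound 1 to compound 4 is expected to be downward, a number 12 percentage points lower from compound 1 to compound 4 (beyond the scatter), about the size of the scatter or a little beyond it. Compound 4 is therefore expected to give 10%, within a range of 0% to 28%.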

Compound 4, a percentage reported as inhibition, at one concentration (the size of the read-out at that concentration, not a potency): 0%
For compound 4 the middle estimate is 10 percentage points above the measured one, and the stated range covers the measured number.
By their numbers in this assay, from the lowest: compounds 4 and 2 (each within the scatter of the next); then compound 1; then compound 3.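

Carboxy in place of 2-fluorophenyl on this aromatic carbon gives a number 22 percentage points lower from compound 1 to compound 4 (beyond the scatter) in this assay and so provides the first direct reading at this place: what sits here changes the result by more than the scatter. Of these two groups, 2-fluorophenyl gives the higher number. No measurement at hand offers a reason for this drop.

Still open, on these data alone, is whether the drop follows from losing the ring or from gaining the carboxy. An unsubstituted phenyl, a methyl or an amine on the same carbon would help to separate these two readings.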